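This account rests on a few compounds, and the source may have more. Where it says the series, first, only, none or still open, it means among the compounds named here.

Compound 1 `CCNc1nc(C(=O)c2ccc(C)s2)c2sccc2n1`: 1260 nM
Compound 2 `O=C(c1cncs1)c1nc(NCc2cccnc2)nc2ccsc12`: 148 nM

In a functional assay on CHO-K1 cells for antagonist activity at adenosine receptor A2b (Homo sapiens), read by FLIPR and calcium flux (on this read-out higher numbers stand for weaker inhibition and lower numbers for stronger inhibition), compound 2 gives 148 nM, the lowest of the two numbers shown. Compound 1 gives 1260 nM, and the gap between these two compounds lies beyond the usual scatter. The two differ in several places at once, so their gap cannot be pinned to any single change.

Compound 3 `CC(C)NC(=O)c1nc(NCc2cccnc2)nc2ccsc12` keeps the core of compound 2 and differs from it in one place: isopropylamino in place of 1,3-thiazol-5-yl on a carbonyl carbon. Read one bond further out, the (1,3-thiazol-5-yl)carbonyl becomes an isopropylcarbamoyl. For the measured compounds named here, no measured pair shows this kind of exchange, so there is no step to lean on. The expectation rests on compound 2 alone: a modest move is expected, more likely toward a higher number than a lower one, and it may not go beyond the scatter at all. For compound 3 in this assay the estimate is 320 nM, with a range from 70 nM to 1500 nM, which means an expected step of a 2.2-fold higher number from compound 2 to compound 3 (0.33 log units; beyond the scatter).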

Compound 3, half-maximal inhibitory concentration: 309 nM
Compound 3: middle estimate off by 1.0-fold (0.02 log units), on the high side, and the stated range covers the measured number.
By their numbers in this assay, from the lowest: compound 2; then compound 3; then compound 1.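

In this assay the change gives a 2.1-fold higher number from compound 2 to compound 3 (0.32 log units; beyond the scatter) and offers the first view of what one exchange does at this place, since it alters only the group on the carbonyl carbon. The step is modest, so the 1,3-thiazol-5-yl ring can give way to isopropylamino, which has no ring and brings a hydrogen-bond donor, while compound 3 still gives 309 nM on the same read-out. Nothing measured here explains why the step has this size.

A single pair cannot separate the loss of the ring from the arrival of the amide hydrogen, so it remains open which of the two accounts for the step. Dimethylamino on the same carbonyl carbon would keep an open-chain amine without that hydrogen, while a phenyl ring would keep an aromatic ring without the nitrogen and sulfur of the thiazole, and how either would read on this assay is unknown.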